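This account rests on a few compounds, and the source may have more. Where it says the series, first, only, none or still open, it means among the compounds named here.

Compound 1 `Nc1nn(C(=O)Nc2ccc(Cc3ccccc3)cc2)c2ccccc12` gives 65900 nM
Compound 2 `Nc1nn(C(=O)Nc2ccc(Cc3ccccc3)cc2)c2ccc(Cl)cc12` gives 58400 nM

In a functional assay on U-251 cells (Homo sapiens) for antiproliferative activity, read by sulforhodamine B assay, with a stated time of 48 h (a lower number here means that less compound is tolerated, a higher number that more compound is tolerated), compound 2 gives 58400 nM and compound 1 gives 65900 nM. Going by the values given here, the two numbers lie within the usual scatter of one another, so compound 2 cannot be told apart from its only neighbour. Among the compounds with values here, the single measured step, a 1.1-fold lower number from compound 1 to compound 2 (0.05 log units; within the scatter), came from a chloro in place of hydrogen on an aromatic carbon, and it did not move the number beyond the scatter.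

Compound 3 `Nc1ccc2c(c1)c(N)nn2C(=O)Nc1ccc(Cc2ccccc2)cc1` differs from compound 2 by amino in place of chloro on an aromatic carbon. Within the data shown here, no measured pair shows an amino at this place, so the chloro step is the only guide, and that step was flat. The expected change is therefore none beyond the scatter, a 1.0-fold higher number from compound 2 to compound 3 (0.01 log units; within the scatter). Compound 3 is estimated at 60000 nM, with a range from 25000 nM to 150000 nM.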

Compound 3, concentration lethal to 50% of the cells: 52000 nM
Estimate against measurement, compound 3: 1.2-fold (0.06 log units) above; low and high end bracket the measured number.
By their numbers in this assay, from the lowest: compounds 3, 2 and 1 (each within the scatter of the next).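

With hydrogen, chloro and amino now compared at this position, the three compounds still cannot be told apart in this assay: the change gives a 1.1-fold lower number from compound 2 to compound 3 (0.05 log units; within the scatter) and, against the unsubstituted compound, a 1.3-fold lower number from compound 1 to compound 3 (0.10 log units; within the scatter), both within the scatter. The amino group brings one hydrogen-bond donor and one hydrogen-bond acceptor where chloro has none, and this difference in counts does not take the number beyond the scatter. No measurement at hand accounts for this flat result.

The compounds shown leave open whether a carboxylic acid or a longer chain, such as a methoxyethyl group, at this position would give a number beyond the scatter. They also leave open whether any change at another place on the shared core would do so.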